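Cyclohexyl carbamate on the methyl-oxazoline core

A few compounds are considered here, and "the series" means these few. Any claim that something is new, unique, unknown or untested is made for them only; others in the source may bear on it.

Two compounds of this series carry numbers in an assay (strain Wistar) for inhibition of Fatty-acid amide hydrolase 1 (Rattus norvegicus), read by scintillation counting; a higher number here means a weaker inhibitor, a lower number a stronger inhibitor. Compound 1 `O=C(NC1CCCCC1)Oc1cccc(C2=NCCO2)c1` gives 1.2 nM in this assay. Compound 2 `C[C@H]1COC(c2cccc(OC(=O)NC3CCCC3)c2)=N1` gives 110 nM in this assay, the higher of the two numbers; its nearest neighbour is compound 1, whose number sits far lower, beyond the scatter. Among the measured compounds shown here, no pair of measured compounds differs in a single place, so no measured step is available.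

Compound 3 `C[C@H]1COC(c2cccc(OC(=O)NC3CCCCC3)c2)=N1` has not yet been measured. It differs from compound 2 by cyclohexyl in place of cyclopentyl on an amide-type nitrogen. For the measured compounds named here, no measured step of this kind stands, so the direction rests on the two values alone: compound 1, the cyclohexyl carbamate, is the stronger of the two compounds measured, and compound 2, the cyclopentyl carbamate, the weaker.

On that basis the step from compound 2 to compound 3 is expected to lower the number by a 7.3-fold lower number from compound 2 to compound 3 (0.87 log units; beyond the scatter), a step beyond the scatter. Compound 3 is estimated at 15 nM in this assay, within a range of 3 nM to 60 nM.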

Compound 3, half-maximal inhibitory concentration: 51 nM
Beside the measured number, compound 3's estimate is 3.4-fold (0.53 log units) below it, within the range that was stated.
By their numbers in this assay, from the lowest: compound 1; then compound 3; then compound 2.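

Compound 3 gives the series its first steps that change one place only, and so separates two changes that the earlier pair of compounds carried together. In this assay cyclohexyl in place of cyclopentyl on an amide-type nitrogen gives a 2.2-fold lower number from compound 2 to compound 3 (0.33 log units; beyond the scatter) and remains a modest step, though one beyond the scatter. Methyl in place of hydrogen on a saturated ring carbon gives a 43-fold higher number from compound 1 to compound 3 (1.63 log units; beyond the scatter) and counts as a large step, so of the two single changes now printed, the methyl on that ring carbon goes with the greater shift in the number and the weaker inhibitor.

Still open, from the compounds shown here alone, is whether cyclohexyl keeps its edge over cyclopentyl on the core of compound 1 without the methyl, and what cycloheptyl or a hexyl chain on the amide-type nitrogen, or ethyl on the saturated ring carbon, would do to the number. No measurement at hand gives a reason for either step.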